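Benzylamino in place of benzyl on the shared core

The source may report more compounds than this note shows. Statements on the series, on what has been measured and on what is new or still open speak of the compounds shown alone.

Compound 1 `O=C(O)Cc1sc(Cc2ccccc2)nc1-c1ccc(Cl)cc1` is examined in an in vitro functional assay on HEK285-7 cells for antagonist activity at prostaglandin D2 receptor 2 (Homo sapiens), read by BRET and beta-arrestin recruitment (a lower number here means a smaller maximal response, a higher number a larger maximal response), where compound 1 gives 50%. Compound 2 `COc1ccc(C(c2ccccc2)c2nc(-c3ccc(Cl)cc3)c(CC(=O)O)s2)cc1` gives 80% in this assay. Compound 1 stands lowest of the two numbers, with compound 2 its nearest neighbour; the step of a number 30 percentage points higher from compound 1 to compound 2 (beyond the scatter) arises from a 4-methoxyphenyl in place of hydrogen on a saturated chain carbon bound to two aromatic carbons. Compound 3 `O=C(O)Cc1sc(NCc2ccccc2)nc1-c1ccc(Cl)cc1` has not been measured in this assay. It differs from compound 1 thus: benzylamino in place of benzyl on an aromatic carbon. Going by the values given here, no measured step changes the aromatic carbon of the five-membered aromatic ring; the single step available alters a different part of the molecule and so does not bear on this change directly. With no direction indicated, a step no larger than the usual scatter is expected, and compound 3 is estimated at 55% with a range from 35% to 75%. This estimate means an expected step of a number 5 percentage points higher from compound 1 to compound 3 (within the scatter).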

Compound 3, largest response reached (reported as efficacy), in percent of the reference or control that the assay uses: 30%
For compound 3 the middle estimate is 25 percentage points above the measured one; the whole stated range lies above it.
By their numbers in this assay, from the lowest: compound 3; then compound 1; then compound 2.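

Going by these compounds alone, the first measured change at this aromatic carbon of the five-membered ring shows that the position affects the maximal response: in this assay, benzylamino in place of benzyl gives a number 20 percentage points lower from compound 1 to compound 3 (beyond the scatter). This step runs in the opposite direction to a number 30 percentage points higher from compound 1 to compound 2 (beyond the scatter), so among the compounds shown, one change lowers the number and the other raises it, each starting from compound 1. No available evidence accounts for the drop seen with the benzylamino group.

The compounds shown leave open whether the linking nitrogen itself matters, which a benzyloxy group, an N-methylbenzylamino group or a phenylamino group could help to separate. They also leave open whether a 4-methoxyphenyl group would raise the number on the benzylamino side chain as it does on the benzyl one.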